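Methoxy in place of chloro on the shared core

The compounds below may be only part of what the source reports. "The series", "measured", "known", "first", "only" and "open" are said of these compounds alone.

Measured so far:
- compound 1 `CCOC(=O)c1c(-c2cccc(-c3ccccc3)c2)[nH]c2cc(OC)ccc2c1=O`: > 21500 nM, a limit
- compound 2 `CCOC(=O)c1c(-c2cccc(-c3ccccc3)c2)[nH]c2cc(Cl)c(Cl)cc2c1=O`: > 21500 nM, a limit

Both compounds were tested in an ADME assay on HepG2 cells (Homo sapiens) for cytotoxicity, read by luminescence, with a stated time of 72 h; on this read-out lower numbers stand for an effect already at smaller amounts and higher numbers for an effect only at larger amounts of compound. Compound 2 stands at > 21500 nM, which is a limit and not a number. Compound 1 stands at > 21500 nM, likewise a limit. For the measured compounds named here, the series so far therefore sits at the limit of > 21500 nM in this assay, at which 2 of the 2 values shown sit, and no measured step is available for either compound.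

Compound 3 `CCOC(=O)c1c(-c2cccc(-c3ccccc3)c2)[nH]c2cc(OC)c(Cl)cc2c1=O` is the next to be read. Going from compound 2, it carries methoxy in place of chloro on an aromatic carbon, ortho to a chloro group: methoxy in place of chloro on an aromatic carbon. It therefore holds a methoxy, as compound 1 does, and a chloro, as compound 2 does.

Going by the values given here, with no measured step to go on, no change beyond the scatter is expected in this assay, and a further limit is the likeliest report. The expected size of the change is a step that the limit leaves unreadable from compound 2 to compound 3. Compound 3 is estimated at 25000 nM, with an expected range of 13000 nM to 45000 nM.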

Compound 3, half-maximal effective concentration: > 21500 nM
Compound 3: only a limit was reported (the forecaster's own chance of this, stated with the estimate: 80%); the middle value is on the limit's open side.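

In this assay compound 3 gives > 21500 nM, which is a limit. The steps from compound 1 and compound 2 to compound 3 cannot be read because all three compounds stand at a limit: the limit of > 21500 nM in this assay, at which 3 of the 3 values shown sit.

Left open is whether methoxy in place of chloro, or chloro in place of hydrogen, changes the read-out at all.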